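The source may report more compounds than this note shows. Statements on the series, on what has been measured and on what is new or still open speak of the compounds shown alone.

Values in an ADME assay on Vero 76 cells (Chlorocebus sabaeus) for cytotoxicity, read by MTT assay, with a stated time of 96 h; on this read-out higher numbers stand for lower toxicity in this test and lower numbers for higher toxicity in this test:
- compound 1 `Cc1ccccc1C1CC(c2ccc(OCc3ccccc3)cc2)=NN1c1ccc(S(N)(=O)=O)cc1`: 100000 nM
- compound 2 `NS(=O)(=O)c1ccc(N2N=C(c3ccccc3)CC2c2ccccc2Cl)cc1`: 26000 nM
- compound 3 `NS(=O)(=O)c1ccc(N2N=C(c3ccc(OCc4ccccc4)cc3)CC2c2ccccc2)cc1`: > 100000 nM (a limit)
- compound 4 `Cc1ccc(C2CC(c3ccc(OCc4ccccc4)cc3)=NN2c2ccc(S(N)(=O)=O)cc2)cc1`: not yet measured

Of the two actual numbers, compound 1 holds the higher, and compound 2 at 26000 nM lies lower, beyond the scatter. The reading for compound 3 is only a limit.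

Compound 4 keeps the core of compound 1 and moves the methyl on the aromatic group: 4-methylphenyl in place of 2-methylphenyl on a saturated ring carbon. In words, 4-methylphenyl stands in place of 2-methylphenyl on a saturated ring carbon.

Going by the values given here, the one measured step that touches this group is a number no lower from compound 1 to compound 3 (the limit leaves the size open). Among the compounds with values here, it ends at the limit of > 100000 nM in this assay, at which 1 of the 3 values shown sits, so its size stays open, and no measured step moves the methyl directly. With compound 1 at 100000 nM, no change beyond the scatter is expected in this assay, and the expected step is a 1.2-fold lower number from compound 1 to compound 4 (0.07 log units; within the scatter). For compound 4 the estimated value is 85000 nM, with an expected range from 35000 nM to 100000 nM.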

Compound 4, half-maximal cytotoxic concentration: 100000 nM
Compound 4: middle estimate off by 1.2-fold (0.07 log units), on the low side; measured number inside the range.
By their numbers in this assay, from the lowest: compound 2; then compounds 1 and 4 (each within the scatter of the next).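

In this assay, the first direct test of moving the methyl on this aryl group gives no change at the digits printed from compound 1 to compound 4 (within the scatter). At this saturated ring carbon next to the ring nitrogen, 2-methylphenyl and 4-methylphenyl therefore cannot be told apart in this test, so the placement of the methyl on this ring carries no readable effect on the read-out for this pair. Compound 3 remains a limit. Adding the methyl gives a number no higher from compound 3 to compound 4 (the limit leaves the size open), and neither step linking this limit to the methylated compounds can be read: the limit of > 100000 nM in this assay, at which 1 of the 4 values shown sits.

Going by these compounds alone, whether the methyl itself matters at this position stays open, as no step that adds or removes it has a readable size. Also open, from the compounds shown here alone, is how this assay would respond to an amine or a carboxylic acid in place of the methyl on this aryl group.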